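A few compounds are considered here, and "the series" means these few. Any claim that something is new, unique, unknown or untested is made for them only; others in the source may bear on it.

Measured compounds:
compound 1 `O=C(O)CCNC(=O)c1ccc(C(Oc2ccc(-n3cc(C(F)(F)F)cn3)cc2)C2CC2)cc1` — 15000 nM
compound 2 `CCCC(Oc1ccc(-n2cc3ccccc3n2)cc1)c1ccc(C(=O)NCCC(=O)O)cc1` — 2000 nM
compound 3 `CCCC(Nc1cc(C)c(-n2cc(C(F)(F)F)cn2)c(C)c1)c1ccc(C(=O)NCCC(=O)O)cc1` — 1400 nM

Of the compounds shown here, three have been measured in a functional assay on cells for antagonist activity at Glucagon receptor (Homo sapiens), read by cAMP accumulation, in the presence of a further agent that is not named here; on this read-out higher numbers stand for weaker inhibition and lower numbers for stronger inhibition. Compound 1 gives 15000 nM, the highest of the three numbers. Compound 2 gives 2000 nM, and compound 3 gives 1400 nM; both stand apart from compound 1 by more than the scatter, so compound 1 is the weakest of the set. Compound 4 `O=C(O)CCNC(=O)c1ccc(C(Oc2ccc(-n3cc(C(F)(F)F)cn3)cc2)C2CCCC2)cc1` has not yet been measured. It differs from compound 1 in one place: cyclopentyl in place of cyclopropyl on a saturated chain carbon bound to an aromatic carbon and an oxygen on an aromatic ring. Compound 2 and compound 3 each carry a different, open-chain group where compound 1 carries the cyclopropyl, and each shows a lower number than compound 1, though both also differ from compound 1 elsewhere, so no single step can be read from them. On that basis the step from compound 1 to compound 4 is expected to be a 3.0-fold lower number from compound 1 to compound 4 (0.48 log units; beyond the scatter), a move toward a lower number and beyond the scatter, though with real uncertainty. Compound 4 is therefore estimated at 5000 nM, within a range from 1500 nM to 15000 nM.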

Compound 4, antagonist equilibrium constant: 4000 nM
Estimate against measurement, compound 4: 1.3-fold (0.10 log units) above, within the range that was stated.
By their numbers in this assay, from the lowest: compounds 3, 2 and 4 (each within the scatter of the next, the first and the last beyond it); then compound 1.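

In this assay, replacing cyclopropyl (3 heavy atoms) with cyclopentyl (5 heavy atoms) on a saturated chain carbon bound to an aromatic carbon and an oxygen on an aromatic ring gives a 3.8-fold lower number from compound 1 to compound 4 (0.57 log units; beyond the scatter), a modest step. Among the compounds shown here, this is the first single change that can be read at this position, and it shows that the number responds to the ring carried there while the rest of compound 1 stays fixed. No measurement given here accounts for the step.

For the compounds shown here, with only this pair, no trend with ring size can be drawn, and it remains open how a cyclobutyl or cyclohexyl ring at the same carbon would read. From the compounds shown here alone, it also remains open whether the same change would have a similar effect with an amine in place of the oxygen.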